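The source may report more compounds than this note shows. Statements on the series, on what has been measured and on what is new or still open speak of the compounds shown alone.

Measured in a functional assay on HCT-116 cells (Homo sapiens) for antiproliferative activity, read by MTT assay, with a stated time of 72 h; on this read-out higher numbers stand for weaker inhibition and lower numbers for stronger inhibition:
- Compound 1 `NC1=NC2(CCSCC2)N(OCCCOc2ccc(Cl)c(Cl)c2)C(N)=N1`: 1 nM
- Compound 2 `CC(C)(C)c1ccc(OCCCON2C(N)=NC(N)=NC23CCSCC3)cc1`: 1 nM
- Compound 3 `Cc1cc(C)cc(OCCCON2C(N)=NC(N)=NC23CCOCC3)c1`: 190 nM

Among these three, compound 3 has the highest number, at 190 nM, which means the weakest inhibition of the set. Compound 1 and compound 2 show the same value, and each lies lower than compound 3 by a margin well beyond the usual scatter.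

The next compound to be tested is compound 4 `Cc1ccc(OCCCON2C(N)=NC(N)=NC23CCOCC3)cc1`. It carries 4-methylphenyl in place of 3,5-dimethylphenyl on an oxygen on a saturated carbon. Among the measured compounds shown here, no two measured compounds differ in only one place, so the data give no direct measure of what such a change does. The expectation therefore rests on compound 3 at 190 nM, and it is deliberately cautious. The expected result in this assay is a 1.3-fold higher number from compound 3 to compound 4 (0.12 log units; within the scatter), a slight rise in the number that stays within the scatter. For compound 4 the estimated value is 250 nM, with an expected range from 70 nM to 900 nM.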

Compound 4, half-maximal inhibitory concentration: 2390 nM
Estimate against measurement, compound 4: 9.6-fold (0.98 log units) below; the whole stated range lies below it.
By their numbers in this assay, from the lowest: compounds 1 and 2 (each within the scatter of the next); then compound 3; then compound 4.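

In this assay, among the compounds shown here, this is the first comparison in the set between compounds that differ in only one place, and 4-methylphenyl in place of 3,5-dimethylphenyl on an oxygen on a saturated carbon gives a 13-fold higher number from compound 3 to compound 4 (1.10 log units; beyond the scatter) as a large step. The two groups have the same aromatic ring, hydrogen-bond counts and charge, and differ by one carbon, 8 heavy atoms against 7, so the group at this position is not interchangeable in this series. No supporting measurement accounts for the size of this step.

The compounds shown leave open whether the same exchange would have a similar effect on the core of compound 1. They also leave open where an unsubstituted phenyl or a 4-methoxyphenyl group would fall at this position.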